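Acid-to-tetrazole swap on the cyclopropyl pyridine arm

This account rests on a few compounds, and the source may have more. Where it says the series, first, only, none or still open, it means among the compounds named here.

Measured so far:
compound 1 `CC(C)n1nc(C(=O)O)cc1C1CC1c1ccc(OCc2c(-c3c(Cl)cccc3Cl)noc2C2CC2)cc1Cl` — 7 nM in an assay on isolated protein for agonist activity at Bile acid receptor (Homo sapiens), read by FRET; on this read-out higher numbers stand for an effect only at larger amounts of compound and lower numbers for an effect already at smaller amounts
compound 2 `O=C(O)c1cncc(C2CC2c2ccc(OCc3c(-c4c(Cl)cccc4Cl)noc3C3CC3)cc2Cl)c1` — 10 nM in this assay

Compound 2 holds the higher of the two numbers in this assay; the nearest neighbour is compound 1, and the step of a 1.4-fold higher number from compound 1 to compound 2 (0.15 log units; within the scatter) stays within the scatter, so the two compounds are not separable on these data.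

Compound 3 `Clc1cc(OCc2c(-c3c(Cl)cccc3Cl)noc2C2CC2)ccc1C1CC1c1ccc(-c2nnn[nH]2)nc1` is not yet measured. Its change from compound 2 is 6-(1H-tetrazol-5-yl)pyridin-3-yl in place of 5-carboxypyridin-3-yl on a saturated ring carbon. Among the measured compounds shown here, no measured step swaps the acid for a tetrazole; the only step in hand, a 1.4-fold higher number from compound 1 to compound 2 (0.15 log units; within the scatter), shows that exchanging the whole acid-bearing heteroaryl on this saturated ring carbon left the number essentially unchanged. For the measured compounds named here, with no direct precedent, the expected step of a 1.5-fold higher number from compound 2 to compound 3 (0.18 log units; within the scatter) in this assay is none beyond the scatter, with a wide allowance either way. Compound 3 is therefore expected to give 15 nM in this assay, in the range 4 nM to 60 nM.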

Compound 3, half-maximal effective concentration: 131 nM
Compound 3: the middle estimate sits 8.7-fold (0.94 log units) below what was measured; the whole stated range lies below it.
By their numbers in this assay, from the lowest: compounds 1 and 2 (each within the scatter of the next); then compound 3.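

On this saturated ring carbon the arm is not interchangeable without limit: in this assay the exchange between the two acid-bearing heteroaryls gave a 1.4-fold higher number from compound 1 to compound 2 (0.15 log units; within the scatter) and stayed within the scatter, whereas 6-(1H-tetrazol-5-yl)pyridin-3-yl gave a 13-fold higher number from compound 2 to compound 3 (1.12 log units; beyond the scatter) and also a 19-fold higher number from compound 1 to compound 3 (1.27 log units; beyond the scatter) as well. Compound 3 therefore stands apart from both acids, so retaining a hydrogen-bond donor in the arm, as counted for both the leaving and the entering group, does not by itself hold the number. No measurement at hand accounts for this difference.

The step from compound 2 to compound 3 changes both the acidic group's identity and its printed place on the pyridine, so these two changes remain unseparated. A 6-carboxypyridin-3-yl or 5-(1H-tetrazol-5-yl)pyridin-3-yl group on the same carbon would tell them apart.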